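This account rests on a few compounds, and the source may have more. Where it says the series, first, only, none or still open, it means among the compounds named here.

Measured so far:
- compound 1 `O=c1ccc2cc(OCc3cc(-c4ccccc4)no3)ccc2o1`: 43300 nM
- compound 2 `O=c1ccc2cc(OCc3cc(-c4cccc(Cl)c4)no3)ccc2o1`: 50600 nM

In a functional assay on HL-60 cells (Homo sapiens) for cytotoxicity, read by MTT assay, with a stated time of 48 h (a lower number here means a stronger inhibitor, a higher number a weaker inhibitor), compound 2 gives 50600 nM, which stands within the scatter of compound 1 at 43300 nM. Among the measured compounds shown here, the two numbers therefore set no order between these compounds.

Compound 3 `O=c1ccc2cc(OCc3cc(-c4ccc(Cl)cc4)no3)ccc2o1` keeps the shared core and differs from compound 2 only in the chlorine-bearing ring: 4-chlorophenyl in place of 3-chlorophenyl on an aromatic carbon. In words, 4-chlorophenyl stands in place of 3-chlorophenyl on an aromatic carbon. For the measured compounds named here, no measured compound yet carries the 4-chlorophenyl group. Going by the values given here, the one measured step that bears on the change is a 1.2-fold higher number from compound 1 to compound 2 (0.07 log units; within the scatter), with chloro in place of hydrogen on an aromatic carbon. That step gives no reason to expect a shift beyond the scatter in this assay, in either direction.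

The expected step is a 1.2-fold lower number from compound 2 to compound 3 (0.08 log units; within the scatter). For compound 3 the estimated value is 42000 nM, with an expected range of 18000 nM to 90000 nM.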

Compound 3, half-maximal inhibitory concentration: 44600 nM
The estimate for compound 3 lay 1.1-fold (0.03 log units) below the measured number; the range from low to high includes it.
By their numbers in this assay, from the lowest: compounds 1, 3 and 2 (each within the scatter of the next).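

Moving the chlorine from 3-chlorophenyl to 4-chlorophenyl, on the aromatic carbon next to the ring nitrogen, produced no readable shift in this assay (a 1.1-fold lower number from compound 2 to compound 3 (0.05 log units; within the scatter)). Set against the plain phenyl group, the 4-chlorophenyl group also stays within the scatter (a 1.0-fold higher number from compound 1 to compound 3 (0.01 log units; within the scatter)), so neither adding chlorine nor changing its place on this ring sets any order among compounds 1, 2 and 3. No evidence is available that bears on these results.

The compounds shown leave open whether an amine or a carboxylic acid on this phenyl ring, in place of chlorine, would move the number beyond the scatter. They also leave open whether a longer chain in place of the phenyl group would do so.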